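Fluoro to chloro exchange, cytotoxicity on kidney cells

The source may report more compounds than this note shows. Statements on the series, on what has been measured and on what is new or still open speak of the compounds shown alone.

Compound 1 `O=C(Nc1nc2ccccc2s1)c1cn(-c2ccccc2)nc1-c1ccc(F)cc1`: 33400 nM in an ADME assay on HEK-293T cells (Homo sapiens) for cytotoxicity, read by MTT assay, with a stated time of 72 h; a higher number here means a weaker inhibitor, a lower number a stronger inhibitor
Compound 2 `O=C(Nc1nc2ccccc2s1)c1cn(-c2ccccc2)nc1-c1ccc(Cl)cc1`: 39600 nM in this assay
Compound 3 `COc1ccc(-c2nn(-c3ccccc3)cc2C(=O)Nc2nc3ccc(F)cc3s2)cc1`: 15400 nM in this assay

Compound 4 `COc1ccc(-c2nn(-c3ccccc3)cc2C(=O)Nc2nc3ccc(Cl)cc3s2)cc1` is not yet measured. It differs from compound 3 by chloro in place of fluoro on an aromatic carbon. The same kind of change, (chloro in place of fluoro on an aromatic carbon), links compound 1 and compound 2 and gave a 1.2-fold higher number from compound 1 to compound 2 (0.07 log units; within the scatter); the place differs, there on a ring of carbon only para to a large group, here on a ring that is part of a fused system of two rings, meta and para to a fused ring. The difference between the two cores of compound 1 and compound 3 is not broken down here; compound 3 sits lower than compound 1 and compound 2, beyond the scatter. The step from compound 3 to compound 4 is expected to be a 1.2-fold higher number from compound 3 to compound 4 (0.07 log units; within the scatter), resting on compound 1 and compound 2 with a 1.2-fold higher number from compound 1 to compound 2 (0.07 log units; within the scatter). Compound 4 is estimated at 18000 nM, between 8000 nM and 40000 nM.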

Compound 4, half-maximal inhibitory concentration: 12600 nM
Compound 4: the middle estimate sits 1.4-fold (0.15 log units) above what was measured; the range from low to high includes it.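

In this assay, the exchange of 6-fluoro-1,3-benzothiazol-2-yl for 6-chloro-1,3-benzothiazol-2-yl gives a 1.2-fold lower number from compound 3 to compound 4 (0.09 log units; within the scatter). Set beside the same exchange on the other core, the two steps do not differ: the same change on two cores in this assay, a 1.2-fold higher number (0.07 log units; within the scatter) from compound 1 to compound 2 and a 1.2-fold lower number (0.09 log units; within the scatter) from compound 3 to compound 4, 1.4-fold (0.16 log units) apart, within the scatter of two such steps. Chloro in place of fluoro therefore carries across these two cores with no readable shift in this assay, but the exchange also sits at a different place on each core, and one pair per core cannot show that it would stay this small on a further core.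

Open, going by these compounds, is how the number would respond to an amine, a carboxylic acid or a longer chain in place of chloro or fluoro on these aromatic carbons. Also open, on these data alone, is whether such a group would behave alike on both cores.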